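A few compounds are considered here, and "the series" means these few. Any claim that something is new, unique, unknown or untested is made for them only; others in the source may bear on it.

Measured so far:
compound 1, `Cc1ccc(S(=O)(=O)NC(C)C)cc1C#Cc1cc(Cl)ccc1OCC(=O)O`, 250 nM;
compound 2, `COCCNS(=O)(=O)c1ccc(C)c(C#Cc2cc(Cl)ccc2OCC(=O)O)c1`, 88 nM;
compound 3, `Cc1ccc(S(=O)(=O)CC(C)C)cc1C#Cc1cc(Cl)ccc1OCC(=O)O`, 120 nM.

All three share a core and differ only in the group on the sulfonyl sulfur. In a functional assay on cells for antagonist activity at prostaglandin D2 receptor 2 (Homo sapiens), read by flow cytometry, with a stated time of 10 min (a higher number here means a weaker inhibitor, a lower number a stronger inhibitor), compound 3 stands second highest of the three numbers: its nearest neighbour is compound 2, and the gap between them is within the scatter, while compound 1 sits furthest away, with a 2.1-fold lower number from compound 1 to compound 3 (0.32 log units; beyond the scatter).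

The unmeasured compound 4 is `Cc1ccc(S(=O)(=O)N(C)C(C)C)cc1C#Cc1cc(Cl)ccc1OCC(=O)O`. The change from compound 3 is isopropyl(methyl)amino in place of isobutyl on a sulfonyl sulfur.

Among the compounds with values here, two measured steps bear on this change. The step of a 2.1-fold lower number from compound 1 to compound 3 (0.32 log units; beyond the scatter) runs almost the other way round: an isobutyl group replaced an isopropylamino group and the number went down. Compound 4 puts an amino group back on the sulfonyl sulfur, now bearing an isopropyl and a methyl. The step of a 2.8-fold lower number from compound 1 to compound 2 (0.45 log units; beyond the scatter) shows that what sits on the sulfonamide nitrogen can move the number by a modest amount. Taken together, the expectation is a modest move back toward compound 1, as a 1.7-fold higher number from compound 3 to compound 4 (0.22 log units; within the scatter), though the added methyl on the nitrogen has no direct precedent among these compounds, so the range is kept wide.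

Compound 4 is therefore estimated at 200 nM, within 80 nM to 500 nM.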

Compound 4, half-maximal inhibitory concentration: 140 nM
Compound 4: the middle estimate sits 1.4-fold (0.15 log units) above what was measured, and the stated range covers the measured number.
By their numbers in this assay, from the lowest: compounds 2, 3, 4 and 1 (each within the scatter of the next, the first and the last beyond it).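

Placing isopropyl(methyl)amino instead of isobutyl on the sulfonyl sulfur leaves the result in this assay within the scatter (a 1.2-fold higher number from compound 3 to compound 4 (0.07 log units; within the scatter)), so this position accepts a sulfonamide with no hydrogen on its nitrogen as well as a sulfone with a branched carbon chain, at least for this pair. Methyl in place of hydrogen on the sulfonamide nitrogen also stays within the scatter (a 1.8-fold lower number from compound 1 to compound 4 (0.25 log units; within the scatter)), as does the exchange of (2-methoxyethyl)amino for isopropyl(methyl)amino (a 1.6-fold higher number from compound 2 to compound 4 (0.20 log units; within the scatter)), so compound 4 cannot be separated from compound 1, compound 2 or compound 3, even though compound 1 and compound 2 are separated from each other by more than the scatter. Nothing shown here gives a measured reason for how these groups compare.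

Going by these compounds, it remains open whether a ring on the sulfonyl sulfur, such as morpholine or piperidine, a basic amine or a longer chain would move the number beyond the scatter. On these data alone, it is also open whether methyl on the nitrogen of the (2-methoxyethyl)amino group would behave as it does on the isopropylamino group.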